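Trifluoromethyl substitution on a thiourea aryl ring

A few compounds are considered here, and "the series" means these few. Any claim that something is new, unique, unknown or untested is made for them only; others in the source may bear on it.

Three diaryl thioureas have been measured in a functional assay on PC-3 cells (Homo sapiens) for antiproliferative activity, read by MTT assay; on this read-out lower numbers stand for stronger inhibition and higher numbers for weaker inhibition. Compound 1 `CNC(=O)c1ccc(Oc2cccc(NC(=S)Nc3ccc(C)c(C)c3)c2)nc1` gives 67400 nM. Compound 2 `CNC(=O)c1ccc(Oc2cccc(NC(=S)Nc3ccc(Br)c(C(F)(F)F)c3)c2)nc1` gives 2670 nM. For the measured compounds named here, compound 3 `CNC(=O)c1ccc(Oc2cccc(NC(=S)Nc3ccc(F)c(F)c3)c2)nc1` gives 23100 nM, the second highest of the three numbers, and the single recorded step to it, a 2.9-fold lower number from compound 1 to compound 3 (0.47 log units; beyond the scatter), is modest. Compound 4 `CNC(=O)c1ccc(Oc2cccc(NC(=S)Nc3cccc(C(F)(F)F)c3)c2)nc1` differs from compound 3 by 3-(trifluoromethyl)phenyl in place of 3,4-difluorophenyl on an amide-type nitrogen. Going by the values given here, no measured step covers exactly this change, but compound 2, which also carries a trifluoromethyl group on that ring, sits well below compound 3 in this assay. A step toward a lower number is therefore expected, a 2.9-fold lower number from compound 3 to compound 4 (0.46 log units; beyond the scatter), without reaching compound 2. Compound 4 is estimated at 8000 nM, within 2500 nM to 25000 nM.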

Compound 4, half-maximal inhibitory concentration: 15400 nM
The estimate for compound 4 lay 1.9-fold (0.28 log units) below the measured number; low and high end bracket the measured number.
By their numbers in this assay, from the lowest: compound 2; then compounds 4 and 3 (each within the scatter of the next); then compound 1.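

Replacing 3,4-difluorophenyl with 3-(trifluoromethyl)phenyl on the amide-type nitrogen gives no real change (a 1.5-fold lower number from compound 3 to compound 4 (0.18 log units; within the scatter)), so this assay does not separate these two rings. The bromo group now stands out, since hydrogen in its place on the aromatic carbon gives a 5.8-fold higher number from compound 2 to compound 4 (0.76 log units; beyond the scatter), while the trifluoromethyl ring still beats 3,4-dimethylphenyl (a 4.4-fold lower number from compound 1 to compound 4 (0.64 log units; beyond the scatter)). Nothing available explains these steps. From the compounds shown here alone, whether bromo works without trifluoromethyl remains open, as does the effect of an amine or a carboxylic acid on this ring.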